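This account rests on a few compounds, and the source may have more. Where it says the series, first, only, none or still open, it means among the compounds named here.

In a functional assay on HCT-15 cells (Homo sapiens) for antiproliferative activity, read by sulforhodamine B assay (on this read-out higher numbers stand for weaker inhibition of growth and lower numbers for stronger inhibition of growth), compound 1 (`CC(C)CCCOc1cccc(O)c1C(=O)/C=C/c1ccc(O)cc1`) gives 11600 nM. Compound 2 (`CC(C)(C)CCOc1cccc(O)c1C(=O)/C=C/c1ccc(C(=O)O)cc1`) gives 2170 nM, but no single change links it to the others, so it does not inform the step considered here. For compound 3 (`O=C(/C=C/c1ccc(O)cc1)c1c(O)cccc1OCCC1CCCCC1`) the result is only a limit, > 30000 nM. Its standing in the series is the limit of > 30000 nM in this assay, at which 1 of the 3 values shown sits.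

Compound 4 (`CCCCOc1cccc(O)c1C(=O)/C=C/c1ccc(O)cc1`) follows from compound 3 by ethyl in place of cyclohexyl on a saturated chain carbon, two bonds along the chain from an oxygen on an aromatic ring. The same difference, cut one bond further out, reads 2-cyclohexylethoxy to butoxy.

For the measured compounds named here, one measured step bears on this place: an at least 2.5-fold higher number from compound 1 to compound 3 (0.41 log units; beyond the scatter), with cyclohexyl in place of isobutyl. Going by that step from compound 1, loss of the cyclohexyl is expected to give a lower number in this assay, by a modest step or somewhat more. Going by the values given here, no measured compound carries butoxy, and the starting point is only a limit, so the range stays wide. The expected step is an at least 2.7-fold lower number from compound 3 to compound 4 (0.43 log units; beyond the scatter). Compound 4 is estimated at 11000 nM, with an expected range of 4000 nM to 28000 nM.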

Compound 4, concentration for 50% growth inhibition: > 30000 nM
Compound 4 ended at the assay's limit; the forecaster's own chance of this, stated with the estimate: 20%; middle value at least 2.7-fold (0.43 log units) away from the limit.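

In this assay compound 4 gives > 30000 nM as a limit of the assay. Methyl in place of isopropyl gives an at least 2.5-fold higher number from compound 1 to compound 4 (0.41 log units; beyond the scatter), so growth inhibition weakens with butoxy as well as with the 2-cyclohexylethoxy of compound 3, and the cyclohexyl is not needed for this loss. Compound 3 and compound 4 cannot be ordered against each other, and the step between them cannot be read: the limit of > 30000 nM in this assay, at which 2 of the 4 values shown sit.

Going by these compounds, whether a longer straight chain or a chain carrying an amine would keep growth inhibition at this place stays open. On these data alone, compound 2 differs from the others in more than one place, so its separate contributions cannot be assigned, and how far butoxy and 2-cyclohexylethoxy really lie beyond the limit is unknown.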